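Swapping Dichlorophenyl for Fluorophenyl Among Inactive Analogues

The source may report more compounds than this note shows. Statements on the series, on what has been measured and on what is new or still open speak of the compounds shown alone.

Compound 1 `COc1ccccc1-c1ncnn1-c1cc(OC)c(OC)c(OC)c1`: > 10000 nM
Compound 2 `COc1cc(-n2ncnc2-c2ccc(F)cc2)cc(OC)c1OC`: > 10000 nM
Compound 3 `COc1cc(-c2ncnn2-c2ccc(Cl)c(Cl)c2)cc(OC)c1OC`: > 10000 nM

In a functional assay on HL-60 cells (Homo sapiens) for antiproliferative activity, read by MTT assay, with a stated time of 72 h (a higher number here means a weaker inhibitor, a lower number a stronger inhibitor), compound 1 gives > 10000 nM, which is a limit of the assay and not a number. In this assay compound 2 gives > 10000 nM, also a limit. In this assay compound 3 gives > 10000 nM, again a limit. Because of the limit of > 10000 nM in this assay, at which 3 of the 3 values shown sit, none of the three compounds can be placed against another. Among the measured compounds shown here, the one measured step, a step that the two limits leave unreadable from compound 1 to compound 2, is therefore unreadable.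

Compound 4 `COc1cc(-c2ncnn2-c2cccc(F)c2)cc(OC)c1OC` has not yet been measured. It differs from compound 3 in one place: 3-fluorophenyl in place of 3,4-dichlorophenyl on an aromatic nitrogen. For the measured compounds named here, no measured step bears directly on this change, since the step from compound 1 to compound 2 swaps a group on an aromatic carbon and its size cannot be read. Going by the values given here, what the three measurements do say is that every compound of this series so far sits at the same limit, so compound 4 is expected to do the same. For compound 4 an estimate of 15000 nM is given, from 4000 nM to 60000 nM. The estimated step that the limit leaves unreadable from compound 3 to compound 4 is expected to stay within scatter, with a limit the most likely outcome.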

Compound 4, half-maximal inhibitory concentration: > 10000 nM
Compound 4 was reported as a limit; the forecaster's own chance of this, stated with the estimate: 85%; the middle value does not contradict the limit.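

In this assay compound 4 gives > 10000 nM which is a limit of the assay and not a number. The change from compound 3 to compound 4 therefore shows no readable step, because both compounds sit at the same limit: the limit of > 10000 nM in this assay, at which 4 of the 4 values shown sit. On these data alone, whether any change to the shared core would give a readable value in this assay stays open.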